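Cytotoxicity Read-Out for a Side-Chain Swap

The source may report more compounds than this note shows. Statements on the series, on what has been measured and on what is new or still open speak of the compounds shown alone.

Of the compounds shown here, three have been measured in an ADME assay on cells (Homo sapiens) for cytotoxicity, read by polymerase chain reaction, with a stated time of 3 days; on this read-out lower numbers stand for higher toxicity in this test and higher numbers for lower toxicity in this test. Compound 1 `Nc1nc(Cl)c(-c2cccs2)c(N[C@@H]2C[C@H](CO)[C@@H](O)[C@H]2O)n1` reaches only the limit of the measurement, > 25000 nM. Compound 2 `CN(C)c1ccc2nc(-c3c(Cl)nc(N)nc3N[C@@H]3C[C@H](CO)[C@@H](O)[C@H]3O)sc2c1` likewise stops at a limit, > 25000 nM. Among the measured compounds shown here, compound 3 `COCCNc1nc(C)c(-c2nc3ccccc3s2)c(N[C@@H]2C[C@H](CO)[C@@H](O)[C@H]2O)n1` gives 21000 nM, the only real number among the three. The other two, compound 1 and compound 2, sit at the limit (the limit of > 25000 nM in this assay, at which 2 of the 3 values shown sit). For the measured compounds named here, compound 3 is therefore the one compound whose toxicity has been pinned to a value, and that value lies close to where the others were cut off.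

Compound 4 `Cc1nc(NCc2cccs2)nc(N[C@@H]2C[C@H](CO)[C@@H](O)[C@H]2O)c1-c1nc2ccccc2s1` differs from compound 3 in a single place: thiophen-2-yl in place of methoxymethyl on a saturated chain carbon bound to a nitrogen on an aromatic ring. Going by the values given here, no pair of measured compounds differs in just one place, so this change has no measured precedent here. The step from compound 3 to compound 4 in this assay is expected to be small, within the scatter, in either direction, a 1.1-fold lower number from compound 3 to compound 4 (0.02 log units; within the scatter). Compound 4 is therefore estimated at 20000 nM, in a range from 8000 nM to 40000 nM.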

Compound 4, half-maximal cytotoxic concentration: 6000 nM
Compound 4: the middle estimate sits 3.3-fold (0.52 log units) above what was measured, outside the stated range (below it).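

In this assay the side chain on the nitrogen is not a silent place: replacing 2-methoxyethyl with (thiophen-2-yl)methyl gives a 3.5-fold lower number from compound 3 to compound 4 (0.54 log units; beyond the scatter) and so moves the read-out towards higher toxicity in this test. Among the compounds shown here, this is the first change whose size can be read, and it shows that a side-chain swap alone, with the rest of the molecule untouched, can shift this read-out. For the compounds shown here, compound 3 and compound 4 form the only pair here that differs in one place and has two real numbers, since the other values stop at a limit: the limit of > 25000 nM in this assay, at which 2 of the 4 values shown sit.

As far as these compounds go, the shift rests on this one pair, so it remains open whether it belongs to the thiophene ring itself or to any ring on this chain. A benzyl group, a plain butyl chain or a 2-aminoethyl chain at this place could help separate those readings.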